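The source may report more compounds than this note shows. Statements on the series, on what has been measured and on what is new or still open speak of the compounds shown alone.

Measured so far:
compound 1 `COc1ccc(C2=N/C(=C\c3cc(Br)cc(Br)c3OC(C)=O)C(=O)NN2c2ncc(-c3ccc(Br)cc3)s2)cc1OC`: 3280 nM
compound 2 `COc1cc(C2=N/C(=C\c3cc(Br)cc(Br)c3OC(C)=O)C(=O)NN2c2ncc(-c3ccc(Br)cc3)s2)cc(OC)c1OC`: 3160 nM
compound 3 `COc1ccc(C2=N/C(=C\c3cc(Br)cc(Br)c3OC(C)=O)C(=O)n3c(C)nc(=S)n32)cc1OC`: 6840 nM

All three were read in a functional assay on MCF7 cells (Homo sapiens) for antiproliferative activity, read by MTT assay, with a stated time of 48 h; on this read-out higher numbers stand for weaker inhibition and lower numbers for stronger inhibition. Compound 1 and compound 2 share one core and differ only by methoxy in place of hydrogen on an aromatic carbon; this change gave a 1.0-fold lower number from compound 1 to compound 2 (0.02 log units; within the scatter), so the two numbers sit within the scatter of each other. Compound 3 carries a different core, and the difference between the two cores is not broken down here. In this assay compound 3 gives the highest of the three numbers, beyond the scatter from both compound 1 and compound 2.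

Compound 4 `COc1cc(C2=N/C(=C\c3cc(Br)cc(Br)c3OC(C)=O)C(=O)n3c(C)nc(=S)n32)cc(OC)c1OC` has not yet been measured. It differs from compound 3 by methoxy in place of hydrogen on an aromatic carbon, the same change as that from compound 1 to compound 2; among these compounds it occurs twice in all. The earlier instance gave a 1.0-fold lower number from compound 1 to compound 2 (0.02 log units; within the scatter). On that basis the step expected here is a 1.0-fold lower number from compound 3 to compound 4 (0.02 log units; within the scatter). The expectation rests on a single pair on another core, so the range is kept wide. Compound 4 is expected to give about 6600 nM in this assay, between 3300 nM and 13000 nM.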

Compound 4, half-maximal inhibitory concentration: 3070 nM
Estimate against measurement, compound 4: 2.1-fold (0.33 log units) above; the whole stated range lies above it.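

In this assay the change from 3,4-dimethoxyphenyl to 3,4,5-trimethoxyphenyl gave a 2.2-fold lower number from compound 3 to compound 4 (0.35 log units; beyond the scatter) as a modest step, whereas on the other core the same change left the two numbers within the scatter of each other. One pair per core cannot fix a size for this step, so neither pair is a firm guide to the other, and nothing here shows what the step would be on a further core. Read one by one, the two pairs fall on opposite sides of the scatter, but set side by side they cannot be separated, so no dependence of this change on the core is shown: the same change on two cores in this assay, a 1.0-fold lower number (0.02 log units; within the scatter) from compound 1 to compound 2 and a 2.2-fold lower number (0.35 log units; beyond the scatter) from compound 3 to compound 4, 2.1-fold (0.33 log units) apart, within the scatter of two such steps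

The aromatic substituents compared here are methoxy groups only, which leaves open how a hydroxyl group, an amine or a carboxylic acid would read at the same place on either core. From the compounds shown here alone, a longer chain, such as ethoxy in place of methoxy, also remains open.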